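The compounds below may be only part of what the source reports. "The series", "measured", "known", "first", "only" and "open" are said of these compounds alone.

Three compounds were measured in a functional assay on cells for positive allosteric modulation of G-protein coupled receptor 68 (Homo sapiens), read by a luciferase reporter and cAMP accumulation, with a stated time of 30 min, at pH 6.8 and pH 8.3, in the presence of a further agent that is not named here; on this read-out lower numbers stand for lower potency and higher numbers for higher potency (the scale is a negative logarithm):

compound 1, `COc1ccc(-c2nc(N)nc(NCc3ccccc3)n2)c(CO)c1`, giving 4.12
compound 2, `CCOc1ccc(-c2nc(N)nc(NCc3ccccc3)n2)c(CO)c1`, giving 4.37
compound 3, `CCOc1ccc(CNc2nc(N)nc(-c3ccccc3CO)n2)cc1`, giving 4.77

Compound 1 and compound 2 share a core and differ in one place: methyl in place of hydrogen on a saturated chain carbon bound to an oxygen on an aromatic ring. This gave a number 0.25 log units higher from compound 1 to compound 2 (within the scatter). Compound 3 is built on a different core; how it differs from compound 1 is not broken down here. Its number in this assay is higher than that of compound 2 and higher than that of compound 1, both beyond the scatter.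

Compound 4, `CC(C)Oc1ccc(CNc2nc(N)nc(-c3ccccc3CO)n2)cc1`, is not yet measured. It differs from compound 3 by methyl in place of hydrogen on a saturated chain carbon bound to an oxygen on an aromatic ring and a saturated chain carbon. This is the same kind of change as that from compound 1 to compound 2, though the place differs: here the carbon is bound to an oxygen on an aromatic ring and a saturated chain carbon, whereas before it was bound only to an oxygen on an aromatic ring. Because that earlier change gave a number 0.25 log units higher from compound 1 to compound 2 (within the scatter), a small step, a number 0.13 log units higher from compound 3 to compound 4 (within the scatter), is expected here too. Compound 4 is therefore estimated at 4.9, likely between 4.4 and 5.4.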

Compound 4, negative logarithm of the antagonist equilibrium constant: 4.99
The estimate for compound 4 lay 0.09 log units below the measured number; low and high end bracket the measured number.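

In this assay, replacing ethoxy with isopropoxy gave a number 0.22 log units higher from compound 3 to compound 4 (within the scatter). Adding a methyl at the end of this kind of chain gave steps that agree on the two cores, so in this small set the change carries from one core to the other with much the same size: the same change on two cores in this assay, a number 0.25 log units higher (within the scatter) from compound 1 to compound 2 and a number 0.22 log units higher (within the scatter) from compound 3 to compound 4, 0.03 log units apart, within the scatter of two such steps. This does not show that the methyl itself makes a real difference, as each step on its own lies within the scatter, and two pairs are too few to set a rule for the series, especially as the methyl goes onto a differently placed carbon in each pair.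

The compounds shown leave open how isopropoxy would read on the core of compound 1, and whether the agreement would hold on a third core. They also leave open what a longer chain such as butoxy, or an amine or a carboxylic acid in the same place, would give in this assay.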